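The compounds below may be only part of what the source reports. "The series", "measured", "known", "first", "only" and "open" are said of these compounds alone.

Of the compounds shown here, two from one series have been measured so far. Compound 1, `CC(C)(C)CC[C@H](c1ccc(C(=O)NCc2nn[nH]n2)cc1)N1C(=O)C(c2cncc(Cl)c2)=N[C@]12CC[C@@H](C(C)(C)C)CC2`, gives 84 nM in an assay on membranes from liver for displacement of a labelled ligand from Glucagon receptor (Mus musculus), read by scintillation counting, with a stated time of 60 min (on this read-out higher numbers stand for weaker inhibition and lower numbers for stronger inhibition), the lowest of the two numbers. Compound 2, `CCCCC[C@H](c1ccc(C(=O)NCc2nn[nH]n2)cc1)N1C(=O)C(c2cc(Cl)cc(Cl)c2)=N[C@]12CC[C@@H](C(C)(C)C)CC2`, differs from it in more than one place and gives 310 nM in this assay, a number that lies beyond the usual scatter from that of compound 1. Compound 3, `CC(C)(C)CC[C@H](c1ccc(C(=O)NCc2nn[nH]n2)cc1)N1C(=O)C(c2ccc(C(F)(F)F)cc2)=N[C@]12CC[C@@H](C(C)(C)C)CC2`, is not yet measured. It differs from compound 1 in one place only: 4-(trifluoromethyl)phenyl in place of 5-chloropyridin-3-yl on a carbon with a double bond to nitrogen. For the measured compounds named here, no measured pair shows this change, so its effect is unknown. The step expected from compound 1 to compound 3 is a 1.8-fold higher number from compound 1 to compound 3 (0.25 log units; within the scatter), a modest move toward higher numbers that may not exceed the scatter. Compound 3 is therefore estimated at 150 nM in this assay, expected within a range of 50 nM to 500 nM.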

Compound 3, half-maximal inhibitory concentration: 190 nM
Compound 3: middle estimate off by 1.3-fold (0.10 log units), on the low side; low and high end bracket the measured number.
By their numbers in this assay, from the lowest: compound 1; then compounds 3 and 2 (each within the scatter of the next).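

Read in this assay at the carbon with a double bond to nitrogen, 4-(trifluoromethyl)phenyl in place of 5-chloropyridin-3-yl gives a 2.3-fold higher number from compound 1 to compound 3 (0.35 log units; beyond the scatter) and so provides the first single-place step at this position. The change is modest and beyond the scatter, and compound 3 still gives a measurable number with a six-membered aromatic ring of carbon only and no hydrogen-bond acceptor in the entering group. Nothing among the available data explains this step.

The ring nitrogen, the chlorine and the trifluoromethyl group all change together in this single step, so their separate contributions remain unresolved. On these data alone, it also remains open how an unsubstituted phenyl, a 3-chlorophenyl or a 5-(trifluoromethyl)pyridin-3-yl group would read at this carbon on the core of compound 1.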